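Morpholine to Piperidine on a Thiosemicarbazone

The source may hold more compounds than are shown below. What is called first, only, known or untested is meant among the compounds shown, and "the series" means these compounds.

Two thiosemicarbazones have been tested in a functional assay on MCF7 cells (Homo sapiens) for cytotoxicity, read by MTT assay, with a stated time of 72 h, tested at 1 uM; on this read-out lower numbers stand for less inhibition of growth and higher numbers for more inhibition of growth at the one concentration tested. Compound 1 `N/C(=N\NC(=S)N1CCCCC1)c1ccccn1` gives 15.4% in this assay. Compound 2 `Cc1cccc(/C(N)=N/NC(=S)N2CCOCC2)n1` gives 11.7% in this assay. Compound 2 shows the smaller of the two numbers, but its gap to compound 1 lies within the scatter, so the two cannot be told apart on this read-out.

Compound 3 `Cc1cccc(/C(N)=N/NC(=S)N2CCCCC2)n1` has not yet been measured. It differs from compound 2 in one place: piperidin-1-yl in place of morpholin-4-yl on a thiocarbonyl carbon. Among the measured compounds shown here, no measured pair shows this change on its own, so there is no measured step to lean on; compound 1 carries the same piperidin-1-yl group and sits at 15.4%, which is the only pointer available.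

The author therefore expects no step beyond the scatter, a number 3.3 percentage points higher from compound 2 to compound 3 (within the scatter), for compound 3. Compound 3 is estimated to give 15% in this assay, within a range from 5% to 27%.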

Compound 3, percent growth inhibition at one concentration: 19.5%
Beside the measured number, compound 3's estimate is 4.5 percentage points below it, and the stated range covers the measured number.
By their numbers in this assay, from the lowest: compounds 2, 1 and 3 (each within the scatter of the next).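

In this assay the change from morpholin-4-yl to piperidin-1-yl on a thiocarbonyl carbon now has a measured step of its own (a number 7.8 percentage points higher from compound 2 to compound 3 (within the scatter)), and that step stays within the scatter, so the two groups cannot be told apart here on the shared core. Among the compounds shown here, the same compound also gives the first reading of methyl in place of hydrogen on an aromatic carbon (a number 4.1 percentage points higher from compound 1 to compound 3 (within the scatter)), and this step likewise cannot be told from the scatter. Nothing available bears on either step beyond the numbers themselves.

The compounds shown leave open whether another group on the thiocarbonyl carbon, such as piperazin-1-yl or dimethylamino, would give a step beyond the scatter. They also leave open whether a longer chain such as ethyl or a methoxy group in place of the methyl would do so.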